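Moving a Halogen Around the Benzoyl Ring

This account rests on a few compounds, and the source may have more. Where it says the series, first, only, none or still open, it means among the compounds named here.

Compound 1, `CC(O)(C(=O)Nc1ccc(C(=O)c2ccccc2F)cc1)C(F)(F)F`, was tested in a functional assay (Cavia porcellus) with sulfonylurea receptors; K-ATP channels (Homo sapiens) as the target (a higher number here means a weaker inhibitor, a lower number a stronger inhibitor), where compound 1 gives 2300 nM. This is the only numerical result available for the set. A second member, compound 2, `CC(O)(C(=O)Nc1ccc(C(=O)c2ccccc2)cc1Cl)C(F)(F)F`, carries a chlorine on the ring that bears the amide nitrogen and no substituent on the benzoyl ring. In this assay compound 2 gives > 30000 nM, which is a limit of the assay rather than a number. Compound 1 and compound 2 differ in two places at once, so their two values can only be read side by side, not as a single step.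

Compound 3, `CC(O)(C(=O)Nc1ccc(C(=O)c2cccc(Cl)c2)cc1)C(F)(F)F`, has not yet been measured. Its difference from compound 1 is 3-chlorophenyl in place of 2-fluorophenyl on a carbonyl carbon. Among the compounds with values here, no measured pair shows what a shift of this kind does here, so no direction can be read from the data. The expectation is a step of a 1.3-fold higher number from compound 1 to compound 3 (0.12 log units; within the scatter) no larger than the usual scatter, and compound 3 is estimated at 3000 nM, within a range from 800 nM to 12000 nM.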

Compound 3, half-maximal inhibitory concentration: > 30000 nM
Compound 3: only a limit was reported (the forecaster's own chance of this, stated with the estimate: 10%); middle value at least 10-fold (1.00 log units) away from the limit.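

Within the data shown here, this is the first change in the set that sits in one place only, and it is large: an at least 13-fold higher number from compound 1 to compound 3 (1.11 log units; beyond the scatter). In this assay compound 3 gives > 30000 nM, which is a limit of the assay and not a number. The two groups match in what can be counted, with the same number of heavy atoms and no hydrogen-bond donors or acceptors, yet exchanging them on this carbonyl carbon moves the read-out well beyond the usual scatter, and the new result joins compound 2 at the same limit: the limit of > 30000 nM in this assay, at which 2 of the 3 values shown sit.

The step changes both the halogen and where it sits on the phenyl ring, so it cannot show which of the two matters; 2-chlorophenyl or 3-fluorophenyl on the same carbonyl carbon would separate them. Also open, going by these compounds, is how this position would respond to something other than a halogen, such as a phenyl ring carrying an amine or a carboxylic acid.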